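The source may hold more compounds than are shown below. What is called first, only, known or untested is meant among the compounds shown, and "the series" means these compounds.

In a functional assay on T-24 cells (Homo sapiens) for antiproliferative activity, read by MTT assay, with a stated time of 72 h; on this read-out lower numbers stand for stronger inhibition and higher numbers for weaker inhibition:
Compound 1 `CC(C)CNC(=N)NC(=N)Nc1ccc(F)cc1F`: 40800 nM
Compound 2 `CC(C)NC(=N)NC(=N)Nc1ccc(C(F)(F)F)cc1`: 4800 nM
Compound 3 `CC(C)CNC(=N)NC(=N)Nc1ccc(C(F)(F)F)cc1`: 3100 nM

Compound 3 and compound 2 lie within the scatter of each other, while compound 1 shows a clearly higher number than both. Compound 4 `CCN(C)C(=N)NC(=N)Nc1ccc(C(F)(F)F)cc1` carries ethyl(methyl)amino in place of isobutylamino on a carbon with a double bond to nitrogen. Among the compounds with values here, one measured step bears on this: isobutyl in place of isopropyl on an amine nitrogen gave a 1.5-fold lower number from compound 2 to compound 3 (0.19 log units; within the scatter). Within the data shown here, no measured step removes a hydrogen-bond donor, so that part of the change is untested. A small rise, near the edge of the scatter, is therefore expected in this assay. The expected change is a 1.9-fold higher number from compound 3 to compound 4 (0.29 log units; within the scatter). For compound 4 the estimated value is 6000 nM, with an expected range of 2500 nM to 15000 nM.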

Compound 4, half-maximal inhibitory concentration: 5700 nM
Beside the measured number, compound 4's estimate is 1.1-fold (0.02 log units) above it; measured number inside the range.
By their numbers in this assay, from the lowest: compounds 3, 2 and 4 (each within the scatter of the next); then compound 1.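

At the carbon with a double bond to nitrogen, ethyl(methyl)amino in place of isobutylamino gave a 1.8-fold higher number from compound 3 to compound 4 (0.26 log units; within the scatter) in this assay, and in place of isopropylamino it gave a 1.2-fold higher number from compound 2 to compound 4 (0.07 log units; within the scatter). Compound 4 has no hydrogen-bond donor in this group, unlike compound 2 and compound 3, yet it stays within the scatter of both, so these numbers do not show that donor to be needed here. No measured evidence accounts for this result. Still open, going by these compounds, is how a ring amine such as morpholine or a longer chain such as n-hexyl would read at this place.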